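A few compounds are considered here, and "the series" means these few. Any claim that something is new, unique, unknown or untested is made for them only; others in the source may bear on it.

Measured compounds:
- compound 1, `O=C(Nc1ccc(S(=O)(=O)N2CCCCC2)c2ccccc12)c1ccccc1`: > 30000 nM
- compound 2, `CCOC(=O)N1CCC(NS(=O)(=O)c2ccc(C(=O)NC3CCCCC3)c3ccccc23)CC1`: 9.5 nM

In an assay on L1.2 cells for binding affinity to C-C chemokine receptor type 8 (Homo sapiens) (a lower number here means a stronger inhibitor, a higher number a weaker inhibitor), compound 1 returns only > 30000 nM, which is a limit of the assay and not a number. Among the measured compounds shown here, compound 2 gives 9.5 nM in this assay, the only measured number in the set. The other entry is the limit of > 30000 nM in this assay, at which 1 of the 2 values shown sits. For the measured compounds named here, no two measured compounds differ in a single place, so no measured step is available to anchor the next change.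

Compound 3, `CCOC(=O)N1CCC(NS(=O)(=O)c2ccc(O)c3ccccc23)CC1`, is the unmeasured analogue of compound 2: hydroxy in place of cyclohexylcarbamoyl on an aromatic carbon. The change strips the cyclohexylcarbamoyl outright, leaving a much smaller substituent. A large loss in this assay is expected, well beyond the usual scatter, with a real chance that only a limit is returned. Compound 3 is estimated at 3000 nM, with a range from 300 nM to 30000 nM. This corresponds to an expected step of a 320-fold higher number from compound 2 to compound 3 (2.50 log units; beyond the scatter).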

Compound 3, inhibition constant: > 5000 nM
Compound 3: only a limit was reported (the forecaster's own chance of this, stated with the estimate: 35%); at least 1.6-fold (0.22 log units) between middle value and limit.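

Compound 3 gives > 5000 nM in this assay, which is a limit of the assay and not a number. Among the compounds shown here, with the rest of compound 2 held constant, hydroxy in place of cyclohexylcarbamoyl on the aromatic carbon gives an at least 520-fold higher number from compound 2 to compound 3 (2.72 log units; beyond the scatter), the only one-place step so far. For the compounds shown here, compound 1 could not show this because it differs from compound 2 in more than one place, so this is the first direct sign that the low value of compound 2 in this assay depends on what occupies this position.

The full size of the step remains unknown, and the compounds shown do not separate the contribution of the cyclohexyl ring from that of the carbamoyl link. A primary carboxamide, a phenylcarbamoyl group or a carboxylic acid at this position would help to distinguish them.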